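The compounds below may be only part of what the source reports. "The series", "measured", "known", "first", "only" and "open" are said of these compounds alone.

Series notes. In a functional assay on UACC-257 cells (Homo sapiens) for inhibition, read by sulforhodamine B assay, with a stated time of 48 h (on this read-out higher numbers stand for weaker inhibition of growth and lower numbers for stronger inhibition of growth), compound 1 `COc1ccc(-c2[nH]c3ccccc3c2/C=C(\C#N)S(=O)(=O)c2ccccc2)cc1` gives 10700 nM, compound 2 `CC(=O)/C(=C\c1c(-c2ccccc2)[nH]c2ccccc12)S(=O)(=O)c1ccccc1` gives 2200 nM, and compound 3 `COc1ccc2[nH]c(-c3ccccc3)c(/C=C(\C#N)S(=O)(=O)c3ccccc3)c2c1` gives 4900 nM. Among these three numbers compound 3 stands second highest: compound 1 shows a higher number and compound 2 a lower one, both gaps beyond the scatter, yet each of those pairs differs from compound 3 in more than one place, so no single step can be read from them. Compound 4 `N#C/C(=C\c1c(-c2ccccc2)[nH]c2ccccc12)S(=O)(=O)c1ccccc1` is not yet measured. It differs from compound 3 by hydrogen in place of methoxy on an aromatic carbon. Among the measured compounds shown here, no measured pair isolates this change, and nothing in the three values points to a direction, so the step is expected to be small, a 1.2-fold lower number from compound 3 to compound 4 (0.09 log units; within the scatter), within the scatter. In this assay compound 4 is estimated at 4000 nM, with a range from 1500 nM to 12000 nM.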

Compound 4, concentration for 50% growth inhibition: 18200 nM
Compound 4: the middle estimate sits 4.6-fold (0.66 log units) below what was measured; measured number above the stated range.
By their numbers in this assay, from the lowest: compound 2; then compound 3; then compounds 1 and 4 (each within the scatter of the next).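

On the ring carbon of the fused system, the methoxy of compound 3 matters in this assay: hydrogen in its place gives a 3.7-fold higher number from compound 3 to compound 4 (0.57 log units; beyond the scatter) and growth inhibition weakens. The same exchange at a different aromatic carbon gives a 1.7-fold higher number from compound 1 to compound 4 (0.23 log units; within the scatter) and stays within the scatter, while cyano in place of acetyl on the chain carbon gives an 8.3-fold higher number from compound 2 to compound 4 (0.92 log units; beyond the scatter) and is the larger step. Nothing on hand explains these steps.

Open, on these data alone, is whether a hydroxyl or a chlorine on that ring carbon would match methoxy. Also open, as far as these compounds go, is whether acetyl would keep its edge over cyano with methoxy present.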